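Adding a ring methyl to compound 1

This account rests on a few compounds, and the source may have more. Where it says the series, first, only, none or still open, it means among the compounds named here.

Compound 2 `CC(=O)N1CCN(C(=O)[C@@H]2CC[C@@H](C)N2C(=O)C2=C(C(C)C)N3C(=N[C@@](C)(c4ccc(Cl)cc4)[C@H]3c3ccc(Cl)cc3)S2)C[C@H]1C` stands at 11000 nM in a functional assay on DLD-1 cells (Homo sapiens) for inhibition, read by luminescence, with a stated time of 3 days (on this read-out higher numbers stand for weaker inhibition of growth and lower numbers for stronger inhibition of growth), and compound 3 `CC(=O)N1CCN(C(=O)[C@@H]2CC[C@@H](C)N2C(=O)C2=C(C(C)C)N3C(=N[C@@](C)(c4ccc(Cl)cc4)[C@H]3c3ccc(Cl)cc3)S2)C[C@@H]1C` stands at 5200 nM on the same scale. Compound 1 `CC[C@@H]1CC[C@@H](C(=O)N2CCN(C(C)=O)CC2)N1C(=O)C1=C(C(C)C)N2C(=N[C@@](C)(c3ccc(Cl)cc3)[C@H]2c2ccc(Cl)cc2)S1` gives 9300 nM and lies within the scatter of each of them.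

Compound 4 `CC[C@@H]1CC[C@@H](C(=O)N2CCN(C(C)=O)[C@H](C)C2)N1C(=O)C1=C(C(C)C)N2C(=N[C@@](C)(c3ccc(Cl)cc3)[C@H]2c2ccc(Cl)cc2)S1` is compound 1 with a single change (methyl in place of hydrogen on a saturated ring carbon): methyl in place of hydrogen on a saturated ring carbon, next to the ring atom that bears an acetyl group. For the measured compounds named here, compounds 2 and 3 both carry a methyl on that ring carbon, but no measured pair shows its addition on its own.

Going by the values given here, the one measured step that bears on the change is a 2.1-fold lower number from compound 2 to compound 3 (0.33 log units; beyond the scatter) and it is modest. That gap is due to the fact that compounds 2 and 3 differ only in the configuration as drawn and it shows that the drawn configuration of this methyl has only a small effect on the read-out. The values of compounds 1, 2 and 3 all fall in a narrow band, so no step beyond the scatter is expected in this assay and no direction is favoured. The expected change is small (a 1.0-fold lower number from compound 1 to compound 4 (0.01 log units; within the scatter)) and stays within the scatter. Compound 4 is expected at 9000 nM (estimated range 4500 nM to 17000 nM).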

Compound 4, concentration for 50% growth inhibition in the DLD-1 assay: 10000 nM
Beside the measured number, compound 4's estimate is 1.1-fold (0.05 log units) below it; the range from low to high includes it.
By their numbers in the DLD-1 assay, from the lowest: compounds 3, 1, 4 and 2 (each within the scatter of the next, the first and the last beyond it).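

The ring methyl can now be read on its own: in the DLD-1 assay there is a 1.1-fold higher number from compound 1 to compound 4 (0.03 log units; within the scatter), and in a physicochemical assay for solubility, read by HPLC, in phosphate buffer, at pH 6.8 (a higher number here means a more soluble compound, a lower number a less soluble compound), there is a 1.4-fold lower number from compound 1 to compound 4 (0.13 log units; within the scatter), with compound 1 at 34 ug/mL and compound 4 at 25 ug/mL, so methyl in place of hydrogen on this saturated ring carbon, next to the ring atom that bears an acetyl group, separates the pair on neither read-out. A second single change gives the same picture, with a further pair that differs in one place giving, in the DLD-1 assay, a 1.1-fold lower number from compound 2 to compound 4 (0.04 log units; within the scatter). The one listed step beyond the scatter thus remains a 2.1-fold lower number from compound 2 to compound 3 (0.33 log units; beyond the scatter) in the DLD-1 assay, and it is a gap of configuration, not of the methyl's presence, due to: the fact that compounds 2 and 3 differ only in the configuration as drawn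

The compounds shown leave open whether the drawn configuration of the ring methyl separates compound 4 from its counterpart of opposite configuration as it separates compound 2 from compound 3. Also open, as far as these compounds go, is whether a different group on this ring carbon, such as a hydroxymethyl, a carboxylic acid or an amine, would give a step beyond the scatter on either read-out.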